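Lengthening the chain from compound 3 to compound 4

The source may report more compounds than this note shows. Statements on the series, on what has been measured and on what is new or still open speak of the compounds shown alone.

Values in an ADME assay on Vero cells (Chlorocebus sabaeus) for cytotoxicity, read by reporter gene assay, with a stated time of 4 days; on this read-out lower numbers stand for stronger inhibition and higher numbers for weaker inhibition:
Compound 1 `CCCCCCC(=O)NCC(C)(C)CC1=C(O)C(=O)c2ccccc2C1=O` gives 24800 nM
Compound 2 `CCCCCCCCC(=O)NCC(C)(C)CC1=C(O)C(=O)c2ccccc2C1=O` gives 16700 nM
Compound 3 `CCCCCCCCCCCCCC(=O)NCC(C)(C)CC1=C(O)C(=O)c2ccccc2C1=O` gives 9810 nM

In this assay compound 3 stands clearly apart from only one of the other two: a 2.5-fold lower number from compound 1 to compound 3 (0.40 log units; beyond the scatter), whereas a 1.7-fold lower number from compound 2 to compound 3 (0.23 log units; within the scatter). Compound 4 `CCCCCCCCCCCCCCCC(=O)NCC(C)(C)CC1=C(O)C(=O)c2ccccc2C1=O` differs from compound 3 by one change: ethyl in place of hydrogen on a saturated chain carbon, ten or more bonds along the chain from a carbonyl carbon. Going by the values given here, the closest precedent is the same ethyl in place of hydrogen further along the series, a 1.5-fold lower number from compound 1 to compound 2 (0.17 log units; within the scatter). The longer pentyl change above, also within the scatter, points the same way. So any further fall should be small. The estimated step, a 1.2-fold lower number from compound 3 to compound 4 (0.09 log units; within the scatter), is expected to stay within the scatter. Compound 4 is estimated at 8000 nM, with an expected range from 4000 nM to 16000 nM.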

Compound 4, half-maximal inhibitory concentration: 5600 nM
Compound 4: the middle estimate sits 1.4-fold (0.15 log units) above what was measured; the range from low to high includes it.
By their numbers in this assay, from the lowest: compounds 4, 3, 2 and 1 (each within the scatter of the next, the first and the last beyond it).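

In this assay, the ethyl change, this far along the chain, gives a step (a 1.8-fold lower number from compound 3 to compound 4 (0.24 log units; within the scatter)) that matches the earlier ethyl step: the same change on two cores in this assay, a 1.5-fold lower number (0.17 log units; within the scatter) from compound 1 to compound 2 and a 1.8-fold lower number (0.24 log units; within the scatter) from compound 3 to compound 4, 1.2-fold (0.07 log units) apart, within the scatter of two such steps. The small steps add up over longer spans, with the heptyl change (a 3.0-fold lower number from compound 2 to compound 4 (0.47 log units; beyond the scatter)) and the nonyl change (a 4.4-fold lower number from compound 1 to compound 4 (0.65 log units; beyond the scatter)) both passing beyond the scatter. The heptyl change also repeats on a second core: the same change on two cores in this assay, a 2.5-fold lower number (0.40 log units; beyond the scatter) from compound 1 to compound 3 and a 3.0-fold lower number (0.47 log units; beyond the scatter) from compound 2 to compound 4, 1.2-fold (0.07 log units) apart, within the scatter of two such steps.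

Going by these compounds, whether a longer chain would move the number further stays open. So does the effect of an amine or a carboxylic acid on the chain.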